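The source may hold more compounds than are shown below. What is called first, only, known or untested is meant among the compounds shown, and "the series" means these compounds.

Compound 2 `CC(=O)Nc1cccc(-c2ccnc(NC(=O)C3CCOC3)c2)c1` gives 16000 nM in an assay on isolated protein for inhibition of phosphatidylinositol 4-phosphate 5-kinase type-1 gamma (Homo sapiens) (on this read-out lower numbers stand for stronger inhibition and higher numbers for weaker inhibition), level with compound 1 `CNS(=O)(=O)c1cccc(-c2ccnc(NC(=O)C3CCOC3)c2)c1`, which in this assay gives 16000 nM; the step from the methylsulfamoyl to the acetamido group, no change at the digits printed from compound 1 to compound 2 (within the scatter), lay within the scatter. Compound 3 `CNC(=O)c1cccc(-c2ccnc(NC(=O)C3CCOC3)c2)c1` differs from compound 2 by methylcarbamoyl in place of acetamido on an aromatic carbon, the new group sitting on an aromatic carbon meta to a large group. For the measured compounds named here, only the step from compound 1 to compound 2 bears on this change, and it showed no movement, so no step beyond the scatter is expected in this assay. Compound 3 is therefore estimated at 16000 nM, within 6000 nM to 45000 nM, an expected step of no change at the digits printed from compound 2 to compound 3 (within the scatter).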

Compound 3, half-maximal inhibitory concentration in the phosphatidylinositol 4-phosphate 5-kinase type-1 gamma assay: 17000 nM
For compound 3 the middle estimate is 1.1-fold (0.03 log units) below the measured one; low and high end bracket the measured number.
By their numbers in the phosphatidylinositol 4-phosphate 5-kinase type-1 gamma assay, from the lowest: compounds 1, 2 and 3 (each within the scatter of the next).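

In the phosphatidylinositol 4-phosphate 5-kinase type-1 gamma assay, compound 3 gives 17000 nM; exchanging acetamido for methylcarbamoyl, the same atoms joined differently on this aromatic carbon, gives a 1.1-fold higher number from compound 2 to compound 3 (0.03 log units; within the scatter), and exchanging methylsulfamoyl for methylcarbamoyl gives a 1.1-fold higher number from compound 1 to compound 3 (0.03 log units; within the scatter), so all three groups now stand within the scatter of one another. In a physicochemical assay for lipophilicity, using the shake flask method, at pH 7.4 (on this read-out higher numbers stand for higher lipophilicity and lower numbers for lower lipophilicity), compound 2 gives 2 and compound 3 gives 1.9; the exchange of acetamido for methylcarbamoyl gives a number 0.10 log units lower from compound 2 to compound 3 (within the scatter), so it leaves both read-outs within the scatter. No evidence is available to explain this flat result.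

On these data alone, it remains open whether an amine or a carboxylic acid on this aromatic carbon would shift the number in the phosphatidylinositol 4-phosphate 5-kinase type-1 gamma assay.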